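This account rests on a few compounds, and the source may have more. Where it says the series, first, only, none or still open, it means among the compounds named here.

Compound 1 has the structure `O=C(CCCCOc1ccccc1)OCC1COCCOCCOCCOCCOCCO1`. In a functional assay on WiDr cells (Homo sapiens) for inhibition, read by sulforhodamine B assay, with a stated time of 48 h (a lower number here means a stronger inhibitor of growth, a higher number a weaker inhibitor of growth), compound 1 gives > 100000 nM, and this is a limit of the assay rather than a number. A second compound, compound 2 with the structure `O=C(CCCCC1CCCCC1)OCC1COCCOCCOCCO1`, was tested the same way. In this assay compound 2 gives > 100000 nM, again a limit and not a number. Among the compounds with values here, both results thus sit at the limit of > 100000 nM in this assay, at which 2 of the 2 values shown sit, so neither compound shows measurable growth inhibition, and no step between them can be sized. Compound 1 therefore stands exactly where every value shown stands: at the limit.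

The compound of interest is compound 3, with the structure `O=C(CCCCc1ccccc1)OCC1COCCOCCOCCOCCOCCO1`. It differs from compound 1 in a single place: phenyl in place of phenoxy on a saturated chain carbon, four bonds along the chain from a carbonyl carbon. Within the data shown here, no step between measured compounds is available to gauge what this change does. Because every value shown sits at the limit of > 100000 nM in this assay, at which 2 of the 2 values shown sit, the step that the limit leaves unreadable from compound 1 to compound 3 is expected to be none beyond the scatter. Compound 3 is accordingly estimated at 150000 nM, within a range from 50000 nM to 500000 nM.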

Compound 3, concentration for 50% growth inhibition: > 100000 nM
Compound 3 ended at the assay's limit (the forecaster's own chance of this, stated with the estimate: 85%); the middle value is on the limit's open side.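

Within the data shown here, compound 3, like compound 1, ends at a limit of the assay rather than at a number, so no step between compound 1 and compound 3 can be read: the limit of > 100000 nM in this assay, at which 3 of the 3 values shown sit. The compounds shown leave open how strongly any of them inhibits growth in this assay, and whether phenyl and phenoxy differ at this place on the chain.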